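Arylsulfonyl variation in a sulfonamide series

The compounds below may be only part of what the source reports. "The series", "measured", "known", "first", "only" and "open" are said of these compounds alone.

Measured compounds:
compound 1, `CC(C)Cc1cc(CNS(=O)(=O)c2cccc(Cl)c2)nn1-c1ccccc1`, 40.8%
compound 2, `Cc1c(Cl)cccc1S(=O)(=O)NCc1cc(CC(C)C)n(-c2ccccc2)n1`, 72.3%

In an assay on isolated protein for binding affinity to 5-hydroxytryptamine receptor 6 (Homo sapiens), tested at 10 uM (on this read-out higher numbers stand for more inhibition at the one concentration tested (going by the name of the read-out) and lower numbers for less inhibition), compound 1 gives 40.8%, and compound 2 gives 72.3%. Compound 2 stands highest of the two numbers; its nearest neighbour is compound 1, and the step of a number 31.5 percentage points higher from compound 1 to compound 2 (beyond the scatter) came with methyl in place of hydrogen on an aromatic carbon.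

Compound 3, `CC(C)Cc1cc(CNS(=O)(=O)c2c(Cl)cccc2Cl)nn1-c1ccccc1`, has not yet been measured in this assay. It differs from compound 2 by 2,6-dichlorophenyl in place of 3-chloro-2-methylphenyl on a sulfonyl sulfur. Among the measured compounds shown here, the one measured step concerns a different change and bears on it only loosely: it shows that a small alteration of the group on the sulfonyl sulfur can move this read-out by a large amount. The change to compound 3 removes the methyl that accompanied that rise and brings in a second chlorine; nothing measured tells what a second chlorine does. The step of a number 22.3 percentage points lower from compound 2 to compound 3 (beyond the scatter) is expected to be a drop of moderate size, with wide uncertainty. Compound 3 is estimated at 50%, within 25% to 75%.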

Compound 3, a percentage reported as inhibition, at one concentration (the size of the read-out at that concentration, not a potency): 59.4%
Compound 3: middle estimate off by 9.4 percentage points, on the low side; measured number inside the range.
By their numbers in this assay, from the lowest: compound 1; then compound 3; then compound 2.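

In this assay, the group on the sulfonyl sulfur stays a sensitive point in the series: a number 12.9 percentage points lower from compound 2 to compound 3 (beyond the scatter), with 2,6-dichlorophenyl in place of 3-chloro-2-methylphenyl, so this replacement does not match the number given by the methyl-bearing group. Among the compounds shown here, the other new comparison, a number 18.6 percentage points higher from compound 1 to compound 3 (beyond the scatter), with 2,6-dichlorophenyl in place of 3-chlorophenyl, shows that a methyl group is not the only change to this aryl group that raises the number, and it places the dichloro group at an intermediate level among the three groups. No measurement at hand accounts for either step or for the order of the three aryl groups.

The compounds shown leave open how this position responds to groups on the aryl ring other than chlorine and methyl, such as methoxy, an amine or a carboxylic acid. Also open, on these data alone, is whether the same order of the three aryl groups would hold if a longer chain replaced the branched alkyl chain on the shared core.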